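Trifluoromethyl for Bromo on the Anilino Ring

The compounds below may be only part of what the source reports. "The series", "measured", "known", "first", "only" and "open" are said of these compounds alone.

Compound 2 `COc1cc(NC(=O)Nc2cc(Nc3cc(Br)ccc3OC)ncn2)cc(OC)c1` gives the highest of the three numbers in a functional assay on NCI-H226 cells (Homo sapiens) for inhibition, read by MTT assay, with a stated time of 48 h, tested at 10 uM; a lower number here means less inhibition, a higher number more inhibition at the concentration tested (going by the name of the read-out): compound 2 gives 42.7%. Compound 1 `COc1ccc(Br)cc1Nc1cc(NC(=O)Nc2c(Cl)cccc2Cl)ncn1` gives 33%, and compound 3 `CCc1cccc(Nc2cc(NC(=O)Nc3cc(OC)cc(OC)c3)ncn2)c1` gives 36.7%. Compound 4 `COc1cc(NC(=O)Nc2cc(Nc3cc(C(F)(F)F)ccc3OC)ncn2)cc(OC)c1` differs from compound 2 in one place: trifluoromethyl in place of bromo on an aromatic carbon, on the ring that carries the methoxy group. The measured steps were small: a number 9.7 percentage points higher from compound 1 to compound 2 (within the scatter) and a number 6 percentage points lower from compound 2 to compound 3 (within the scatter). The second step, which swaps the whole 5-bromo-2-methoxyphenyl group for 3-ethylphenyl, bears most directly on exchanging the bromo for trifluoromethyl, and it stayed within the scatter. The step of a number 2.7 percentage points lower from compound 2 to compound 4 (within the scatter) is therefore expected to be none beyond the scatter. Compound 4 is estimated at 40%, within 27% to 54%.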

Compound 4, a percentage reported as inhibition, at one concentration (the size of the read-out at that concentration, not a potency): 60%
Beside the measured number, compound 4's estimate is 20 percentage points below it, and the stated range ends below it.
By their numbers in this assay, from the lowest: compounds 1, 3 and 2 (each within the scatter of the next); then compound 4.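

On the ring that carries the methoxy group, the aromatic carbon para to that methoxy group responded in this assay: trifluoromethyl in place of bromo gave a number 17.3 percentage points higher from compound 2 to compound 4 (beyond the scatter), the first step among these compounds to leave the scatter. The earlier steps shown here, each exchanging a whole aryl group, had stayed within it. No measurement shown here gives a reason for this gain.

The compounds shown leave open whether a nitrile or a methyl on this carbon would give a similar number. Also open, from the compounds shown here alone, is whether the same exchange would hold with 2,6-dichlorophenyl on the amide-type nitrogen.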